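From 4-(trifluoromethyl)benzyl to 3-methoxybenzyl in a growth assay

The compounds below may be only part of what the source reports. "The series", "measured", "known", "first", "only" and "open" are said of these compounds alone.

Measured in a functional assay on Jurkat cells (Homo sapiens) for inhibition, read by CCK-8 assay, with a stated time of 48 h; a lower number here means a stronger inhibitor of growth, a higher number a weaker inhibitor of growth:
Compound 1 `Cc1ccccc1Nc1nc(Nc2ccccc2)ncc1Cl`: > 100000 nM (a limit, not a number)
Compound 2 `Cc1ccccc1Nc1nc(Nc2ccc(N3CCCCC3)cn2)ncc1Cl`: > 100000 nM (a limit, not a number)
Compound 3 `CN1CCN(c2ccc(Nc3ncc(Cl)c(NCc4ccc(C(F)(F)F)cc4)n3)nc2)CC1`: 7960 nM

Of the three measured compounds, only compound 3 has a number, 7960 nM. Compound 1 and compound 2 give no number, only (the limit of > 100000 nM in this assay, at which 2 of the 3 values shown sit).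

Compound 4 `COc1cccc(CNc2nc(Nc3ccc(N4CCN(C)CC4)cn3)ncc2Cl)c1` has not yet been measured. It differs from compound 3 in one place: 3-methoxyphenyl in place of 4-(trifluoromethyl)phenyl on a saturated chain carbon bound to a nitrogen on an aromatic ring. A 3-methoxyphenyl stands in place of a 4-(trifluoromethyl)phenyl on a saturated chain carbon bound to a nitrogen on an aromatic ring. Cut one bond further out, the same difference reads 4-(trifluoromethyl)benzyl to 3-methoxybenzyl.

Among the measured compounds shown here, no pair of measured compounds differs in just one place, so no measured step shows what such a change does in this assay. For the measured compounds named here, with compound 3 at 7960 nM as the sole number to go on, no change beyond the scatter is expected, only a slight lean towards weaker growth inhibition. The expected step is a 1.5-fold higher number from compound 3 to compound 4 (0.18 log units; within the scatter), an estimate with wide uncertainty. For compound 4 the estimated value is 12000 nM, with an expected range from 3000 nM to 45000 nM.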

Compound 4, concentration for 50% growth inhibition: 73400 nM
Compound 4: middle estimate off by 6.1-fold (0.79 log units), on the low side; measured number outside the range, above it.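

In this assay, among the compounds shown here, this is the first step that can be read at this position, and it is large: 3-methoxyphenyl in place of 4-(trifluoromethyl)phenyl on a saturated chain carbon bound to a nitrogen on an aromatic ring gives a 9.2-fold higher number from compound 3 to compound 4 (0.96 log units; beyond the scatter). The earlier compounds shown here offered no such pair, so only now is it clear that the number responds to the group carried at this position, even with the rest of the molecule unchanged. Compound 4 still gives a number, but with little room left before the limit that the assay reaches for other compounds in the series: the limit of > 100000 nM in this assay, at which 2 of the 4 values shown sit.

What the compounds leave open is which part of the change matters, since 4-(trifluoromethyl)benzyl and 3-methoxybenzyl differ both in the group on the ring and in the number of its ring position, and a single step cannot separate the two. Nor do they show how a plain benzyl, or a benzyl carrying a chlorine or a nitrile, would stand in this series.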